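The source may hold more compounds than are shown below. What is called first, only, known or untested is meant among the compounds shown, and "the series" means these compounds.

In a functional assay on DU-145 cells (Homo sapiens) for cytotoxicity, read by sulforhodamine B assay, with a stated time of 48 h (a lower number here means a stronger inhibitor, a higher number a weaker inhibitor), two compounds sharing one core have been measured. Compound 1 `C[C@H]1CC[C@@H]2[C@@H](OC(=O)[C@]23CC(c2ccc([N+](=O)[O-])cc2)=NO3)[C@]2(C)C(=O)C=C[C@@]12O` gives 7000 nM, and compound 2 `C[C@H]1CC[C@@H]2[C@@H](OC(=O)[C@]23CC(c2ccccc2F)=NO3)[C@]2(C)C(=O)C=C[C@@]12O` gives 24000 nM, the higher number and so the weaker of the pair. Compound 3 `Cc1ccc(C2=NO[C@]3(C2)C(=O)O[C@@H]2[C@H]3CC[C@H](C)[C@]3(O)C=CC(=O)[C@@]23C)cc1` changes one group of compound 2: 4-methylphenyl in place of 2-fluorophenyl on a carbon with a double bond to nitrogen. Within the data shown here, the only measured step at this place is modest, a 3.4-fold higher number from compound 1 to compound 2 (0.54 log units; beyond the scatter). That step involves a different pair of groups, so it offers only a rough guide to size. A small step toward a lower number is expected, a 1.7-fold lower number from compound 2 to compound 3 (0.23 log units; within the scatter). The expected value for compound 3 is 14000 nM, with an estimated range of 5000 nM to 40000 nM.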

Compound 3, half-maximal inhibitory concentration: 14000 nM
Compound 3: middle estimate and measured number agree at the digits printed; measured number inside the range.
By their numbers in this assay, from the lowest: compounds 1, 3 and 2 (each within the scatter of the next, the first and the last beyond it).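

With 4-methylphenyl on this carbon, the change from 2-fluorophenyl gives a 1.7-fold lower number from compound 2 to compound 3 (0.23 log units; within the scatter), and methyl in place of nitro on the aromatic carbon gives a 2.0-fold higher number from compound 1 to compound 3 (0.30 log units; within the scatter). Compound 3 therefore cannot be told apart from either of the other two, although those two differ from each other beyond the scatter. Nothing measured here explains these differences. Still open, as far as these compounds go, is what would happen with an amine or a carboxylic acid on the aromatic ring, or with a plain alkyl chain replacing that ring.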